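Sulfonamide Replaces Amide in a Cytotoxicity Series

A few compounds are considered here, and "the series" means these few. Any claim that something is new, unique, unknown or untested is made for them only; others in the source may bear on it.

In an ADME assay on Vero cells (Chlorocebus sabaeus) for cytotoxicity, read by MTT assay, with a stated time of 72 h (on this read-out lower numbers stand for stronger inhibition and higher numbers for weaker inhibition), compound 1 `O=C(Nc1nc(-c2cccc(F)c2)cs1)c1ccc([N+](=O)[O-])o1` gives 51600 nM, compound 2 `CC(=O)Nc1cccc(-c2csc(NC(=O)c3ccc([N+](=O)[O-])o3)n2)c1` gives 57600 nM, and compound 3 `O=C(Nc1nc(-c2cccc(NC(=O)C3CC3)c2)cs1)c1ccc([N+](=O)[O-])o1` gives 35700 nM. Compound 3 holds the lowest of the three numbers, yet both gaps stay within the scatter: a 1.4-fold lower number from compound 1 to compound 3 (0.16 log units; within the scatter) and a 1.6-fold lower number from compound 2 to compound 3 (0.21 log units; within the scatter). The step to compound 4 `CS(=O)(=O)Nc1cccc(-c2csc(NC(=O)c3ccc([N+](=O)[O-])o3)n2)c1` is methylsulfonyl in place of cyclopropylcarbonyl on a nitrogen on an aromatic ring. The closest comparison is a 1.6-fold lower number from compound 2 to compound 3 (0.21 log units; within the scatter), which also altered the group on that nitrogen, and a 1.1-fold higher number from compound 1 to compound 2 (0.05 log units; within the scatter) likewise left the read-out essentially unchanged. With these steps all within the scatter, a step of a 1.3-fold higher number from compound 3 to compound 4 (0.10 log units; within the scatter) in this assay is expected, meaning none beyond the scatter. Compound 4 is therefore estimated at 45000 nM, with a range from 20000 nM to 100000 nM.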

Compound 4, half-maximal inhibitory concentration: < 2820 nM
Compound 4 gave a limit, no number; the forecaster's own chance of this, stated with the estimate: 10%; at least 15-fold (1.20 log units) between middle value and limit.
By their numbers in this assay, from the lowest: compounds 3, 1 and 2 (each within the scatter of the next). At a limit, below all of these: compound 4.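

In this assay compound 4 gave a limit, not a number: the limit of < 2820 nM in this assay, at which 1 of the 4 values shown sits. At this nitrogen on an aromatic ring, methylsulfonyl moves the read-out beyond the scatter, with an at least 12-fold lower number from compound 3 to compound 4 (1.10 log units; beyond the scatter) against cyclopropylcarbonyl and an at least 20-fold lower number from compound 2 to compound 4 (1.31 log units; beyond the scatter) against acetyl, whereas exchanging those two carbonyl groups did not. Methanesulfonamido in place of fluoro gives an at least 18-fold lower number from compound 1 to compound 4 (1.26 log units; beyond the scatter), so among these four compounds the shift goes with the sulfonyl group and not merely with a substituted nitrogen.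

As far as these compounds go, how far the number falls stays open: compound 4 holds only a limit. Whether the shift would survive a longer chain or a phenyl ring on the sulfonyl group is also left open.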